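From 2,4-difluorophenyl to 3,5-difluorophenyl

A few compounds are considered here, and "the series" means these few. Any claim that something is new, unique, unknown or untested is made for them only; others in the source may bear on it.

Measured in an ADME assay on microsomes from liver (Mus musculus) for metabolic stability; a lower number here means that the compound disappears faster, a higher number that the compound lasts longer:
compound 1 `Cc1cccc(NC(=O)c2nn(C)c(-c3ccccc3)c2C)n1` gives 0.3 h
compound 2 `Cc1cccc(NC(=O)c2nn(C)c(-c3ccc(F)cc3)c2C)n1` gives 0.6 h
compound 3 `Cc1cccc(NC(=O)c2nn(C)c(-c3ccc(F)cc3F)c2C)n1` gives 0.633 h

Compound 3 stands level with compound 2 within the scatter, and it sits clear of compound 1, with a 2.1-fold higher number from compound 1 to compound 3 (0.32 log units; beyond the scatter). The next compound to be tested is compound 4 `Cc1cccc(NC(=O)c2nn(C)c(-c3cc(F)cc(F)c3)c2C)n1`. It keeps the shared core, and 3,5-difluorophenyl takes the place of 2,4-difluorophenyl (3,5-difluorophenyl in place of 2,4-difluorophenyl on an aromatic carbon).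

Among the measured compounds shown here, three measured steps bear on this change, all of them additions of fluoro rather than moves. The first addition gave a 2.0-fold higher number from compound 1 to compound 2 (0.30 log units; within the scatter), and the further one gave a 1.1-fold higher number from compound 2 to compound 3 (0.02 log units; within the scatter). None of them shifts a fluoro group around the phenyl ring, so the data hold no direct measure of this swap. The best anchor is compound 3, at 0.633 h, with some room left toward compound 1, at 0.3 h. No change beyond the scatter is expected in this assay, and the expected move is a 1.3-fold lower number from compound 3 to compound 4 (0.10 log units; within the scatter). For compound 4 the estimate is 0.5 h, with an expected range of 0.25 h to 1 h.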

Compound 4, half-life: 0.3 h
Beside the measured number, compound 4's estimate is 1.7-fold (0.22 log units) above it; the range from low to high includes it.
By their numbers in this assay, from the lowest: compounds 1, 4, 2 and 3 (each within the scatter of the next, the first and the last beyond it).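

In this assay, among the compounds shown here, 2,4-difluorophenyl and 3,5-difluorophenyl carry the same atoms joined differently, yet the swap gives a 2.1-fold lower number from compound 3 to compound 4 (0.32 log units; beyond the scatter), so this is the first measure showing that at this position the arrangement of the fluoro groups on the phenyl ring matters, and not only their presence. The fluoro groups do not by themselves hold the number up: with 3,5-difluorophenyl in place of phenyl there is no change at the digits printed from compound 1 to compound 4 (within the scatter), and with 3,5-difluorophenyl in place of 4-fluorophenyl there is a 2.0-fold lower number from compound 2 to compound 4 (0.30 log units; within the scatter), which leaves those pairs level within the scatter. Nothing on hand accounts for the difference between the two difluorophenyl arrangements.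

From the compounds shown here alone, only hydrogen and fluoro appear on this phenyl ring, so it remains open how a chloro, methoxy or nitrile group would behave there. Going by these compounds, all four compounds also keep the shared core unchanged, so the effect of an amine or a longer chain elsewhere on it remains unknown.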